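Azole-bearing amides in a dopamine receptor binding series

The source may report more compounds than this note shows. Statements on the series, on what has been measured and on what is new or still open speak of the compounds shown alone.

Three compounds have been measured in an assay on brain for displacement of a labelled ligand from D(3) dopamine receptor (Rattus norvegicus); a higher number here means a weaker inhibitor, a lower number a stronger inhibitor:

Compound 1, `CCCN(CC[C@H]1CC[C@H](NC(=O)/C=C/c2cccc(OC)c2)CC1)[C@H]1CCc2nc(N)sc2C1`, gives 9.3 nM.
Compound 2, `CCCN(CC[C@H]1CC[C@H](NC(=O)c2ccc(-n3ccnc3)cc2)CC1)[C@H]1CCc2nc(N)sc2C1`, gives 1.9 nM.
Compound 3, `CCCN(CC[C@H]1CC[C@H](NC(=O)c2cccc(-n3cncn3)c2)CC1)[C@H]1CCc2nc(N)sc2C1`, gives 3 nM.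

Compound 3 holds the second highest of these three numbers. Against compound 1 the gap is clear: a 3.1-fold lower number from compound 1 to compound 3 (0.49 log units; beyond the scatter). Against compound 2 it is not: a 1.6-fold higher number from compound 2 to compound 3 (0.20 log units; within the scatter).

Compound 4, `CCCN(CC[C@H]1CC[C@H](NC(=O)c2ccc(-n3cccn3)cc2)CC1)[C@H]1CCc2nc(N)sc2C1`, has not yet been measured. It differs from compound 3 in one place: 4-(1H-pyrazol-1-yl)phenyl in place of 3-(1H-1,2,4-triazol-1-yl)phenyl on a carbonyl carbon. For the measured compounds named here, two measured steps bear on this. Both a 4.9-fold lower number from compound 1 to compound 2 (0.69 log units; beyond the scatter) and a 3.1-fold lower number from compound 1 to compound 3 (0.49 log units; beyond the scatter) show that an azole-substituted phenyl on the carbonyl carbon lowers the number compared with the ethenyl group of compound 1, and a 1.6-fold higher number from compound 2 to compound 3 (0.20 log units; within the scatter) shows that swapping one such azolylphenyl for another stays within the scatter. Compound 4 is therefore expected to give no step beyond the scatter in this assay. For compound 4 the expected step is a 1.2-fold lower number from compound 3 to compound 4 (0.08 log units; within the scatter). For compound 4 the estimate is 2.5 nM, with a range from 1 nM to 6 nM.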

Compound 4, inhibition constant: 3 nM
The estimate for compound 4 lay 1.2-fold (0.08 log units) below the measured number, within the range that was stated.
By their numbers in this assay, from the lowest: compounds 2, 3 and 4 (each within the scatter of the next); then compound 1.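

With 1H-pyrazol-1-yl in place of 1H-imidazol-1-yl on an aromatic carbon, only the azole is exchanged, and in this assay this gives a 1.6-fold higher number from compound 2 to compound 4 (0.20 log units; within the scatter). The exchange of 3-(1H-1,2,4-triazol-1-yl)phenyl for 4-(1H-pyrazol-1-yl)phenyl on a carbonyl carbon gives no change at the digits printed from compound 3 to compound 4 (within the scatter), while a third azolylphenyl also stands apart from the ethenyl group, with a 3.1-fold lower number from compound 1 to compound 4 (0.49 log units; beyond the scatter). Nothing available explains why these azolylphenyl groups give such similar numbers.

Whether the lower numbers relative to compound 1 belong to the azole or to the phenyl itself remains open, as a plain phenyl on the carbonyl carbon is not among the compounds shown. Also open, on these data alone, is how a phenyl carrying a carboxylic acid or an amine in place of the azole would read in this assay.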